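Replacing the aromatic ring of compound 2 with cyclohexyl

The compounds below may be only part of what the source reports. "The series", "measured", "known", "first", "only" and "open" are said of these compounds alone.

Compound 1 `O=C(O)CCC/C=C\C[C@H]1/C(=N/OC(c2ccccc2)c2ccccc2)CC[C@@H]1NS(=O)(=O)c1ccc(Cl)cc1` gives 17000 nM
Compound 2 `O=C(O)CCC/C=C\C[C@H]1/C(=N/OCc2ccc(C(F)(F)F)cc2)CC[C@@H]1NS(=O)(=O)c1ccc(Cl)cc1` gives 200 nM
Compound 3 `C[C@@H]1CC/C(=N\OC(c2ccccc2)c2ccccc2)[C@H]1C/C=C\CCCC(=O)O` gives 800 nM

In a functional assay (plasma) for inhibition, with Homo sapiens as the target (on this read-out higher numbers stand for weaker inhibition and lower numbers for stronger inhibition), compound 2 has the lowest number of the three at 200 nM and is therefore the strongest inhibitor here, with its gaps to compound 3 and compound 1 both beyond the usual scatter.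

The next compound is compound 4 `O=C(O)CCC/C=C\C[C@H]1/C(=N/OCC2CCCCC2)CC[C@@H]1NS(=O)(=O)c1ccc(Cl)cc1`, which has not yet been measured. The change cyclohexyl in place of 4-(trifluoromethyl)phenyl on a saturated chain carbon bound to an oxygen puts cyclohexyl in place of 4-(trifluoromethyl)phenyl on a saturated chain carbon bound to an oxygen. For the measured compounds named here, no measured pair shows this exact swap, so any forecast is loose. Compound 1 at 17000 nM and compound 2 at 200 nM carry different groups at this spot and lie far apart, so a change here may well show. The expected step of a 4.5-fold higher number from compound 2 to compound 4 (0.65 log units; beyond the scatter) is a moderate rise to a higher number, meaning weaker inhibition beyond the scatter. For compound 4 the estimated value is 900 nM in this assay with an expected range from 200 nM to 4500 nM on repeated measurement.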

Compound 4, half-maximal inhibitory concentration: 1700 nM
Beside the measured number, compound 4's estimate is 1.9-fold (0.28 log units) below it, and the stated range covers the measured number.
By their numbers in this assay, from the lowest: compound 2; then compound 3; then compound 4; then compound 1.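

In this assay, putting cyclohexyl in place of 4-(trifluoromethyl)phenyl gives an 8.5-fold higher number from compound 2 to compound 4 (0.93 log units; beyond the scatter), with the rest of the molecule unchanged. For the compounds shown here, this is the first one-place comparison, and it shows that the group on this saturated chain carbon bound to an oxygen affects inhibition. A non-aromatic ring of carbon only is tolerated here, but it gives weaker inhibition than 4-(trifluoromethyl)phenyl, and nothing available explains this difference.

This single swap removes the aromatic ring and the trifluoromethyl group together, so their separate contributions cannot be told apart. On these data alone, how a plain phenyl ring or a pyridine ring would behave on this carbon remains open, and either would help show which feature of the departing group matters.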